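The compounds below may be only part of what the source reports. "The series", "measured", "known", "first", "only" and "open" are said of these compounds alone.

In a functional assay on MCF7 cells (Homo sapiens) for antiproliferative activity, read by MTT assay, with a stated time of 48 h (on this read-out lower numbers stand for stronger inhibition and higher numbers for weaker inhibition), compound 1 `COc1cc(-c2nnc3c(OC)cc(-c4ccc5c(ccn5C)c4)cn23)cc(OC)c1OC` gives 49 nM. Within the data shown here, compound 2 `COc1cc(-c2nnc3c(OC4CCC4)cc(-c4ccc5c(ccn5C)c4)cn23)cc(OC)c1OC` shares its core but has cyclobutyl in place of methyl on an oxygen on an aromatic ring, and compound 2 gives 125 nM, the highest of the two numbers so far and therefore the weaker result. The change between them is a 2.6-fold higher number from compound 1 to compound 2 (0.41 log units; beyond the scatter), a modest step that lies beyond the scatter.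

Compound 3 `COc1cc(-c2nnc3c(OC4CC4)cc(-c4ccc5c(ccn5C)c4)cn23)cc(OC)c1OC` has not yet been measured. It alters the same group, with cyclopropyl in place of cyclobutyl on that oxygen: cyclopropyl in place of cyclobutyl on an oxygen on an aromatic ring. Among the measured compounds shown here, only one measured step bears on this change, the modest rise of a 2.6-fold higher number from compound 1 to compound 2 (0.41 log units; beyond the scatter), and that single step cannot establish a trend. Since cyclopropyl is a smaller ring than cyclobutyl, compound 3 may fall between the two measured compounds, so a small drop is expected in this assay. The expected change is a 1.6-fold lower number from compound 2 to compound 3 (0.19 log units; within the scatter), which may not clearly exceed the scatter. For compound 3, the estimated value is 80 nM, with an expected range of 40 nM to 160 nM.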

Compound 3, half-maximal inhibitory concentration: 118 nM
Beside the measured number, compound 3's estimate is 1.5-fold (0.17 log units) below it; measured number inside the range.
By their numbers in this assay, from the lowest: compound 1; then compounds 3 and 2 (each within the scatter of the next).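

In this assay, exchanging the four-membered ring on this oxygen for the three-membered one gives a 1.1-fold lower number from compound 2 to compound 3 (0.03 log units; within the scatter), so compound 2 and compound 3 cannot be told apart here, and the size of the ring makes no readable difference between these two groups. The smaller ring also does not recover the result of the methyl compound: cyclopropyl in place of methyl gives a 2.4-fold higher number from compound 1 to compound 3 (0.38 log units; beyond the scatter), so both ring-bearing compounds now stand on the weaker side of compound 1, with cyclobutyl in place of methyl giving a 2.6-fold higher number from compound 1 to compound 2 (0.41 log units; beyond the scatter) as the matching step. This holds for these three compounds only, none of them goes against it, and no measurement is available here that would explain it.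

From the compounds shown here alone, what remains open is whether the loss follows from having a ring at all on this oxygen, or whether an open chain such as ethyl or isopropyl would already behave like cyclopropyl and cyclobutyl. Going by these compounds, it is equally open how a free hydroxyl at this place, or a longer chain ending in an amine, would read in this assay when set against the methyl ether of compound 1.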